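Replacing pyridin-3-yl on the amide of compound 2

A few compounds are considered here, and "the series" means these few. Any claim that something is new, unique, unknown or untested is made for them only; others in the source may bear on it.

Compound 1 `COc1ccc(-c2nc(/N=C(\N)NC3CCCCC3)sc2-c2ccc(OC)cc2)cc1` gives a limit in a functional assay (aorta) with Rattus norvegicus as the target (on this read-out higher numbers stand for an effect only at larger amounts of compound and lower numbers for an effect already at smaller amounts), > 100 uM, and not a number. For the measured compounds named here, compound 2 `COc1ccc(-c2nc(CNC(=O)c3cccnc3)sc2-c2ccc(OC)cc2)cc1` gives 8.2 uM in this assay, the only true number so far, and it serves as the starting point here. Compound 3 `COc1ccc(-c2nc(CNC(=O)CSC)sc2-c2ccc(OC)cc2)cc1` carries (methylsulfanyl)methyl in place of pyridin-3-yl on a carbonyl carbon, ((methylsulfanyl)methyl in place of pyridin-3-yl on a carbonyl carbon). Going by the values given here, the single measured step, an at least 12-fold lower number from compound 1 to compound 2 (1.08 log units; beyond the scatter), is large, but it replaces the whole group on an aromatic carbon and starts from a limit. It therefore gives no direct measure for a change on the carbonyl carbon, and the expectation rests mainly on compound 2 at 8.2 uM. Only a small step toward a higher number is expected, a 1.8-fold higher number from compound 2 to compound 3 (0.26 log units; within the scatter). The estimate for compound 3 is 15 uM, with the measurement expected between 4 uM and 60 uM.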

Compound 3, concentration for half-maximal effect: 6 uM
Estimate against measurement, compound 3: 2.5-fold (0.40 log units) above; the measured number falls inside the stated range.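

With (methylsulfanyl)methyl in place of pyridin-3-yl on the carbonyl carbon, the change gives a 1.4-fold lower number from compound 2 to compound 3 (0.14 log units; within the scatter) in this assay. For the compounds shown here, this position therefore accepts a group with no ring in place of the six-membered aromatic ring without a change that can be told from the scatter, which the earlier compounds could not show. Compound 1 gives only a limit, so an at least 16-fold lower number from compound 1 to compound 3 (1.22 log units; beyond the scatter) is large but marks a bound on the replacement of a whole group, not a size: the limit of > 100 uM in this assay, at which 1 of the 3 values shown sits.

The compounds shown leave open whether the sulfur of the new group matters, which a plain propyl chain on the same carbonyl carbon would test. They also leave open whether an amine or a carboxylic acid at the end of a longer chain there would move the number beyond the scatter.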